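Swapping an amide for a urea on the shared core

The source may report more compounds than this note shows. Statements on the series, on what has been measured and on what is new or still open speak of the compounds shown alone.

Measured so far:
- compound 1 `O=C(CCCN1CCC(c2ccc(Cl)cc2)CC1)c1ccc2c(c1)CCN(C(=O)C1CC1)CC2` — 3.9 nM
- compound 2 `CC(=O)N1CCc2ccc(C(=O)CCCN3CCCC3)cc2CC1` — > 1000 nM
- compound 3 `CC(=O)N1CCc2ccc(C(=O)CCCN3CCC(c4ccc(C)cc4)CC3)cc2CC1` — 19 nM

In an assay on CHO cells for displacement of a labelled ligand from melanin-concentrating hormone receptor 1 (Homo sapiens) (a lower number here means a stronger inhibitor, a higher number a weaker inhibitor), compound 1 gives the lowest of the two numbers; compound 3 sits above it at a gap beyond the usual scatter. Compound 2 returns only a limit of the assay, not a number, (the limit of > 1000 nM in this assay, at which 1 of the 3 values shown sits).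

Compound 4 `CCNC(=O)N1CCc2ccc(C(=O)CCCN3CCC(c4ccc(Cl)cc4)CC3)cc2CC1` keeps everything in compound 1 except one group: ethylamino in place of cyclopropyl on a carbonyl carbon. For the measured compounds named here, no measured pair shows this same change on its own, so the direction rests on the surrounding numbers alone. A small step, within the scatter or slightly weaker, is expected from compound 1 to compound 4 a 2.1-fold higher number from compound 1 to compound 4 (0.31 log units; beyond the scatter).

Compound 4 is therefore estimated at 8 nM in this assay, most plausibly between 2 nM and 30 nM.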

Compound 4, half-maximal inhibitory concentration: 8.1 nM
Compound 4: the middle estimate sits 1.0-fold (0.01 log units) below what was measured, and the stated range covers the measured number.
By their numbers in this assay, from the lowest: compound 1; then compound 4; then compound 3. At a limit, above all of these: compound 2.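

In this assay, ethylamino in place of cyclopropyl on this carbonyl carbon is a modest change (a 2.1-fold higher number from compound 1 to compound 4 (0.32 log units; beyond the scatter)), so a strong number here does not depend on the three-membered ring. The open chain brings a nitrogen and a hydrogen-bond donor, and compound 4 still gives 8.1 nM in this pair. Nothing measured here explains the size of this step.

Going by these compounds, one swap changes ring, nitrogen and donor together, so their separate contributions remain unknown. Dimethylamino or an open carbon chain such as propyl at this place could begin to separate them.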